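This account rests on a few compounds, and the source may have more. Where it says the series, first, only, none or still open, it means among the compounds named here.

Two amides on the shared core are in hand. Compound 1 `CN1CCC(c2c[nH]c3cnc(NC(=O)c4ccc(F)cc4)cc23)CC1` is one of them, and in an assay for binding affinity to 5-hydroxytryptamine receptor 1F (Homo sapiens), read by radioligand binding (a lower number here means a stronger inhibitor, a higher number a weaker inhibitor), compound 1 gives 13 nM. Compound 2 `CCCCCC(=O)Nc1ccc2[nH]cc(C3CCN(C)CC3)c2n1` carries a pentyl on the carbonyl carbon, and in this assay compound 2 gives 13 nM, level with compound 1 at the digits shown and within the scatter of it. For the measured compounds named here, no single-point step between measured compounds is available in this set. Compound 3 `COc1ccccc1C(=O)Nc1ccc2[nH]cc(C3CCN(C)CC3)c2n1` is the next entry and is not yet measured. The change from compound 2 to compound 3 is 2-methoxyphenyl in place of pentyl on a carbonyl carbon. Since the two groups already tested on the carbonyl carbon give the same reading in this assay, only a small step is expected here, without a clear direction beyond the scatter, as a 1.2-fold higher number from compound 2 to compound 3 (0.06 log units; within the scatter). Compound 3 is therefore estimated at about 15 nM in this assay, within a range of 4 nM to 60 nM.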

Compound 3, inhibition constant: 20 nM
For compound 3 the middle estimate is 1.3-fold (0.12 log units) below the measured one; the measured number falls inside the stated range.
By their numbers in this assay, from the lowest: compounds 1, 2 and 3 (each within the scatter of the next).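

For the compounds shown here, replacing pentyl with 2-methoxyphenyl on the carbonyl carbon gives a 1.5-fold higher number from compound 2 to compound 3 (0.19 log units; within the scatter) in this assay, the first single-place comparison. At this position, therefore, an open chain and a six-membered aromatic ring of carbon only, carrying a hydrogen-bond acceptor that pentyl lacks, read alike within the scatter. No supporting data bear on why the two groups read alike.

Still open, on these data alone, is whether plain phenyl reads like 2-methoxyphenyl, which would show whether the methoxy group contributes anything separately from the ring. Also open, as far as these compounds go, is how this position responds to a chain longer than pentyl, or to a group bearing an amine or a carboxylic acid, either of which could test how far this flat response extends.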